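Swapping the Aryl Group on a Shared Core

A few compounds are considered here, and "the series" means these few. Any claim that something is new, unique, unknown or untested is made for them only; others in the source may bear on it.

Measured so far:
compound 1 `C=CCn1c(=O)/c(=C\c2cc(F)ccc2C)[nH]c(=O)/c1=C\c1ccccc1OC` — 5600 nM
compound 2 `C=CCn1c(=O)/c(=C\c2ccccc2F)[nH]c(=O)/c1=C\c1ccccc1OC` — 31300 nM
compound 3 `COc1ccccc1/C=c1/[nH]c(=O)/c(=C\c2nc[nH]c2C(C)(C)C)[nH]c1=O` — 90 nM

In a functional assay on Huh-7 cells (Homo sapiens) for cytotoxicity, read by CCK-8 assay, with a stated time of 72 h (on this read-out lower numbers stand for stronger inhibition and higher numbers for weaker inhibition), compound 1 stands second highest of the three numbers. Its nearest neighbour is compound 2, reached by a 5.6-fold higher number from compound 1 to compound 2 (0.75 log units; beyond the scatter); the furthest is compound 3, whose far lower number comes with changes in more than one place. Compound 4 `C=CCn1c(=O)/c(=C\c2cccc(Cl)c2Cl)[nH]c(=O)/c1=C\c1ccccc1OC` differs from compound 1 by 2,3-dichlorophenyl in place of 5-fluoro-2-methylphenyl on a double-bonded chain carbon bound to an aromatic carbon. Within the data shown here, the one step that bears on this is the change at the same place from compound 1 to compound 2, which was modest and upward. A step of similar or smaller size is therefore expected, a 1.3-fold higher number from compound 1 to compound 4 (0.10 log units; within the scatter). Compound 4 is estimated at 7000 nM, within 2500 nM to 20000 nM.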

Compound 4, half-maximal inhibitory concentration: 1200 nM
Compound 4: the middle estimate sits 5.8-fold (0.77 log units) above what was measured; measured number outside the range, below it.
By their numbers in this assay, from the lowest: compound 3; then compound 4; then compound 1; then compound 2.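

At this position, the result shows that the aryl swap can also lower the number in this assay: moving to 2,3-dichlorophenyl gives (a 4.7-fold lower number from compound 1 to compound 4 (0.67 log units; beyond the scatter)), opposite in direction to the earlier step. The same group also gives a large drop from the 2-fluorophenyl analogue (a 26-fold lower number from compound 2 to compound 4 (1.42 log units; beyond the scatter)), so the choice of aryl group matters strongly on this shared core. Nothing available here explains these differences.

From the compounds shown here alone, it remains open how an aryl group carrying an amine or a carboxylic acid would behave at this place. It is also unknown whether a single chlorine would match the two chlorines of compound 4.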